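This account rests on a few compounds, and the source may have more. Where it says the series, first, only, none or still open, it means among the compounds named here.

Measured so far in a functional assay on A549 cells (Homo sapiens) for cytotoxicity, read by MTT assay; a higher number here means a weaker inhibitor, a lower number a stronger inhibitor:

- compound 1, `CCOC(=O)C12C(=O)OCC=C1COC2c1cccc(Cl)c1`, gives 28400 nM
- compound 2, `CCOC(=O)C12C(=O)OCC=C1COC2c1ccc(Br)cc1`, gives only a limit of the assay, > 1000000 nM
- compound 3, `CCOC(=O)C12C(=O)OCC=C1COC2c1cccs1`, gives only a limit of the assay, > 1000000 nM

Compound 3 therefore stands at the limit of this assay rather than on a number; the same limit, (the limit of > 1000000 nM in this assay, at which 2 of the 3 values shown sit), holds two of the three values seen so far. Against compound 1 the step of an at least 35-fold higher number from compound 1 to compound 3 (1.54 log units; beyond the scatter) is large, a clear loss. Against compound 2 the step that the two limits leave unreadable from compound 2 to compound 3 cannot be read, since both sit at the limit.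

Compound 4, `CCOC(=O)C12C(=O)OCC=C1COC2c1ccccn1`, differs from compound 3 by pyridin-2-yl in place of thiophen-2-yl on a saturated ring carbon. Within the data shown here, the steps that bear on this change are an at least 35-fold higher number from compound 1 to compound 3 (1.54 log units; beyond the scatter), large, and a step that the two limits leave unreadable from compound 2 to compound 3, unreadable. Both tell that moving away from 3-chlorophenyl at this carbon has so far sent the value to the limit; neither shows that any aromatic group other than 3-chlorophenyl returns a number. Pyridin-2-yl is a further heteroaryl at the same carbon, so compound 4 is expected to remain at or near the limit in this assay, with a step of an at least 1.6-fold lower number from compound 3 to compound 4 (0.22 log units; that floor lies within the scatter) that is expected to be unreadable beyond the scatter. The estimate for compound 4 is 600000 nM, expected between 60000 nM and 3000000 nM.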

Compound 4, half-maximal inhibitory concentration: > 1000000 nM
Compound 4: only a limit was reported (the forecaster's own chance of this, stated with the estimate: 70%); middle value at least 1.6-fold (0.22 log units) from the limit.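

Pyridin-2-yl adds a six-membered aromatic ring with one hetero atom to the groups tried on this saturated ring carbon, and in this assay it also returns no number, so neither the larger ring nor the change from sulfur to nitrogen brings a readable value back: the limit of > 1000000 nM in this assay, at which 3 of the 4 values shown sit.

The step of an at least 35-fold higher number from compound 1 to compound 4 (1.54 log units; beyond the scatter) is large, and among the four compounds only compound 1, with its 3-chlorophenyl group, gives a number, 28400 nM. The steps among compound 2, compound 3 and compound 4 cannot be read, so no order can be drawn among 4-bromophenyl, thiophen-2-yl and pyridin-2-yl.

Still open, on these data alone, is whether the number for compound 1 rests on the chlorine itself or on where it sits, a question that 3-bromophenyl, 4-chlorophenyl or plain phenyl on the same carbon would address. Also open, as far as these compounds go, is how the value responds to changes elsewhere on the core of compound 1, such as a carboxylic acid or an amide in place of the ethoxycarbonyl group.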